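A few compounds are considered here, and "the series" means these few. Any claim that something is new, unique, unknown or untested is made for them only; others in the source may bear on it.

Measured compounds:
compound 1 `Nc1cccc(/C=C2\SC(=O)N(Cc3ccc(F)cc3)C2=O)c1` — 86000 nM
compound 2 `CC(C)(C)c1ccc(CN2C(=O)S/C(=C\c3cccc(N)c3)C2=O)cc1` — 145000 nM
compound 3 `C=C(Br)C(=O)Nc1cccc(/C=C2\SC(=O)N(Cc3ccc(C(F)(F)F)cc3)C2=O)c1` — 820 nM

In a functional assay on HeLa cells (Homo sapiens) for cytotoxicity, read by cell counting, with a stated time of 4 days (on this read-out lower numbers stand for stronger inhibition and higher numbers for weaker inhibition), compound 1 gives 86000 nM. Compound 2, its nearest neighbour on the numbers shown, sits within the scatter of compound 1, so the two cannot be ordered. Among the measured compounds shown here, compound 3 differs from compound 1 in more than one place; compound 3 gives 820 nM, a far lower number, but no single step connects it to compound 1.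

The new compound is compound 4 `Nc1cccc(/C=C2\SC(=O)N(Cc3cccc(F)c3)C2=O)c1`. It differs from compound 1 in one place: 3-fluorophenyl in place of 4-fluorophenyl on a saturated chain carbon bound to an amide-type nitrogen in a ring. For the measured compounds named here, the only measured single step is a 1.7-fold higher number from compound 1 to compound 2 (0.23 log units; within the scatter), which exchanges the group on the benzyl ring for a different one; it does not touch the position of the fluorine on that ring, so nothing measured bears directly on the change to compound 4. Going by the values given here, the one step that does exist on the same ring stayed within the scatter, and the shift of a fluorine from one ring position to another is a small change on the same ring, so no step beyond the scatter is expected in this assay.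

Compound 4 is therefore estimated to give 90000 nM, in the range 35000 nM to 230000 nM, meaning an expected step of a 1.0-fold higher number from compound 1 to compound 4 (0.02 log units; within the scatter).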

Compound 4, half-maximal inhibitory concentration: > 250000 nM
Compound 4: a limit, no number; the forecaster's own chance of this, stated with the estimate: 10%; at least 2.7-fold (0.44 log units) between middle value and limit.
By their numbers in this assay, from the lowest: compound 3; then compounds 1 and 2 (each within the scatter of the next). At a limit, above all of these: compound 4.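

In this assay, compound 4 carries a limit and not a number: the limit of > 250000 nM in this assay, at which 1 of the 4 values shown sits. Exchanging 4-fluorophenyl for 3-fluorophenyl, on a saturated chain carbon bound to an amide-type nitrogen in a ring, gives an at least 2.9-fold higher number from compound 1 to compound 4 (0.46 log units; beyond the scatter), so this place in the series responds to a change that leaves the atoms of the group the same and only joins them differently. Among the compounds shown here, the one earlier step at this group, a 1.7-fold higher number from compound 1 to compound 2 (0.23 log units; within the scatter), stayed within the scatter and showed no such response, even though it exchanged fluoro for the larger tert-butyl; the series therefore now holds a readable step at this place, and it comes from the smaller change in atoms of the two.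

The true size of the step stays open, since only a lower bound on it can be read, and the compounds shown give no account of why moving the fluorine matters here. Also open, going by these compounds, is how this place responds to other groups on the same ring, such as 3-chlorophenyl, 3-aminophenyl or a ring carrying a carboxylic acid, and whether any of them returns the number towards that of compound 1.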